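From Methoxy to Ethoxycarbonyl on a Shared Core

The source may hold more compounds than are shown below. What is called first, only, known or untested is meant among the compounds shown, and "the series" means these compounds.

Compound 1 `Clc1ccc(Sc2c(-c3ccc(Cl)cc3)[nH]c3ccc(Cl)cc23)cc1` in a functional assay on SK-MEL-28 cells (Homo sapiens) for inhibition, read by MTT assay, with a stated time of 72 h (a lower number here means a stronger inhibitor of growth, a higher number a weaker inhibitor of growth), gives 34000 nM.
Compound 2 `COc1ccc2[nH]c(-c3ccc(Cl)cc3)c(Oc3ccc(Cl)cc3)c2c1` in this assay gives 57000 nM.
Compound 3 `CCOC(=O)C1CCN(C(=S)Sc2c(-c3ccc(Br)cc3)n(C)c3ccccc23)CC1` in this assay gives 78000 nM.

Among these three numbers, compound 2 holds the second highest. Its nearest neighbour is compound 3, whose number is higher by an amount that lies within the usual scatter of repeated measurements; compound 1 gives a lower number, and that gap too lies within the scatter. The three compounds therefore cannot be told apart on what has been measured, and none of them can be called the stronger or weaker inhibitor of growth on this evidence.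

Compound 4 `CCOC(=O)c1ccc2[nH]c(-c3ccc(Cl)cc3)c(Oc3ccc(Cl)cc3)c2c1` differs from compound 2 in a single place: ethoxycarbonyl in place of methoxy on an aromatic carbon. Among the measured compounds shown here, no pair of measured compounds shows this same change, so there is no measured step to lean on, and the three measured numbers give no direction to extrapolate from. The expected step is no change at the digits printed from compound 2 to compound 4 (within the scatter), meaning none beyond the scatter and in no fixed direction. For compound 4 the estimated value in this assay is 57000 nM, with a range from 20000 nM to 160000 nM.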

Compound 4, concentration for 50% growth inhibition: 28000 nM
Compound 4: the middle estimate sits 2.0-fold (0.31 log units) above what was measured; low and high end bracket the measured number.
By their numbers in this assay, from the lowest: compounds 4, 1, 2 and 3 (each within the scatter of the next, the first and the last beyond it).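

In this assay, among the compounds shown here, ethoxycarbonyl in place of methoxy on this aromatic carbon gives a 2.0-fold lower number from compound 2 to compound 4 (0.31 log units; beyond the scatter), the first change here that can be read at a single place, as no earlier pair differed in only one. This shows that the number is not indifferent to what sits at this position of the shared core: a group of 5 heavy atoms, with a double bond outside the aromatic rings, can replace one of 2 heavy atoms and give a stronger inhibitor of growth, though the step is modest. No measurement at hand explains this step.

Going by these compounds, a single step cannot separate the contribution of the carbonyl from that of the ethyl part of the ester, so it remains open whether a carboxylic acid, a methyl ester or an amide at this position would give a similar number. On these data alone, it is also open whether the same change would produce a step of similar size and direction on the core of compound 1.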